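The source may report more compounds than this note shows. Statements on the series, on what has been measured and on what is new or still open speak of the compounds shown alone.

Compound 2 `C=C1C[C@]23C[C@@]1(O)CC[C@H]2c1ccc(O)c(C)c1[C@@H]3Cn1cc(-c2ccc(F)cc2)nn1` in a functional assay on SMMC-7721 cells (Homo sapiens) for cytotoxicity, read by MTT assay, with a stated time of 4 days (on this read-out higher numbers stand for weaker inhibition and lower numbers for stronger inhibition), gives > 20000 nM, and this is a limit of the assay rather than a number. Compound 1 `C=C1C[C@]23C[C@@]1(O)CC[C@H]2c1ccc(O)c(C)c1[C@@H]3Cn1cc(-c2ccc(C(F)(F)F)cc2)nn1` likewise gives only > 20000 nM, again a limit. The step that the two limits leave unreadable from compound 1 to compound 2 therefore cannot be read, because of the limit of > 20000 nM in this assay, at which 2 of the 2 values shown sit. Compound 3 `C=C1C[C@]23C[C@@]1(O)CC[C@H]2c1ccc(O)c(C)c1[C@@H]3Cn1cc(-c2ccc(OC)cc2)nn1` differs from compound 2 by methoxy in place of fluoro on an aromatic carbon. No measured step rises above that limit, so nothing shown tells how large the change in this assay will be or in which direction. Compound 3 is expected to sit near 25000 nM, within 10000 nM to 60000 nM, most probably again as a limit. The expected step is a step that the limit leaves unreadable from compound 2 to compound 3.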

Compound 3, half-maximal inhibitory concentration: > 20000 nM
Compound 3 was reported as a limit; the forecaster's own chance of this, stated with the estimate: 75%; the middle value lies beyond the limit too.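

Within the data shown here, no step among compound 1, compound 2 and compound 3 can be read, because each gives only a limit rather than a number: the limit of > 20000 nM in this assay, at which 3 of the 3 values shown sit. As far as these compounds go, whether trifluoromethyl, fluoro and methoxy differ at all in this assay stays open.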